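The compounds below may be only part of what the source reports. "The series", "measured", "known", "first", "only" and "open" are said of these compounds alone.

Measured compounds:

Compound 1, `CCc1c(C)n(C(=O)N2CCCCC2)oc1=O`, gives 18 nM in an assay (strain Wistar) for inhibition of Hormone-sensitive lipase (Rattus norvegicus), read by spectrophotometry; a lower number here means a stronger inhibitor, a higher number a weaker inhibitor.
Compound 2, `Cc1c(C2CCOCC2)c(=O)on1C(=O)N1CCCCC1`, gives 71 nM in this assay.
Compound 3, `Cc1c(C(C)C)c(=O)on1C(=O)N(C)Cc1ccc(F)cc1`, gives 111 nM in this assay.

Among the three measured compounds, compound 3 shows the highest number in this assay. Its value and that of compound 2 lie within the usual scatter of each other, so no order can be read between them; the gap to compound 1, however, is beyond the scatter, and compound 1 is the stronger inhibitor of the two.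

The next compound, compound 4, `Cc1c(C(C)C)c(=O)on1C(=O)N(C)CC(N)=O`, arises from compound 3 by the change (carbamoyl in place of 4-fluorophenyl on a saturated chain carbon bound to an amide-type nitrogen). Among the compounds with values here, the only measured step in this set, a 3.9-fold higher number from compound 1 to compound 2 (0.60 log units; beyond the scatter), concerns a substituent on an aromatic carbon of the shared core and not the chain on the amide-type nitrogen, so it does not bear directly on the present change. Within the data shown here, with no measured step at the place in question, the expectation for compound 4 in this assay rests on the change itself: a ring with seven heavy atoms leaves and a small group with a donor and an acceptor enters. The estimate is for a weaker inhibitor, by a 4.1-fold higher number from compound 3 to compound 4 (0.61 log units; beyond the scatter), with wide uncertainty. Compound 4 is therefore expected to give about 450 nM in this assay, with a likely range from 110 nM to 2500 nM.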

Compound 4, half-maximal inhibitory concentration: > 1000 nM
Compound 4: a limit, no number (the forecaster's own chance of this, stated with the estimate: 15%); at least 2.2-fold (0.34 log units) between middle value and limit.
By their numbers in this assay, from the lowest: compound 1; then compounds 2 and 3 (each within the scatter of the next). At a limit, above all of these: compound 4.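

Within the data shown here, this is the first measured step at the chain on the amide-type nitrogen, and it shows that this place counts in this assay: carbamoyl in place of 4-fluorophenyl on a saturated chain carbon gives an at least 9.0-fold higher number from compound 3 to compound 4 (0.95 log units; beyond the scatter). The earlier step concerned a substituent on an aromatic carbon of the shared core, so only this result shows that the inhibition of compound 3 does not survive the exchange of its aromatic ring for the small carbamoyl group. The value of compound 4 is a limit and not a number, so the step gives only the smallest size the change can have: the limit of > 1000 nM in this assay, at which 1 of the 4 values shown sits.

The compounds shown leave open whether the loss of the 4-fluorophenyl ring or the entry of the carbamoyl carries the step, and how far past the limit compound 4 lies. They also leave open how an unsubstituted phenyl, a carboxylic acid or an amine on the same chain carbon would read, and whether the step would hold with ethyl or oxan-4-yl on the aromatic carbon of the shared core.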